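The source may hold more compounds than are shown below. What is called first, only, known or untested is meant among the compounds shown, and "the series" means these compounds.

Compound 1, `N/C(=N/NC(CC(=O)c1ccc(-n2ccnc2)cc1)c1ccccc1)c1ccccn1`, in an ADME assay on Vero cells (Chlorocebus sabaeus) for cytotoxicity, read by MTT assay, with a stated time of 72 h (on this read-out higher numbers stand for lower toxicity in this test and lower numbers for higher toxicity in this test), gives 63500 nM.
Compound 2, `N/C(=N/NC(CC(=O)c1ccc(-n2ccnc2)cc1)c1cccc([N+](=O)[O-])c1)c1ccccn1`, in this assay gives 28700 nM.
Compound 3, `N/C(=N/NC(CC(=O)c1ccc(-n2ccnc2)cc1)c1ccc(Cl)cc1)c1ccccn1`, in this assay gives 78800 nM.

Among these three, compound 3 has the highest number; compound 1 lies nearest to it, within the scatter, while compound 2 lies furthest, beyond the scatter. Compound 4, `N/C(=N/NC(CC(=O)c1ccc(-n2ccnc2)cc1)c1cccc(Cl)c1)c1ccccn1`, has not yet been measured. It differs from compound 3 only in this way: 3-chlorophenyl in place of 4-chlorophenyl on a saturated chain carbon bound to an amine nitrogen and a saturated chain carbon.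

Within the data shown here, two measured steps bear on it. The step of a 1.2-fold higher number from compound 1 to compound 3 (0.09 log units; within the scatter) shows that adding a chloro at the 4-chlorophenyl position changed little. The step of a 2.7-fold higher number from compound 2 to compound 3 (0.44 log units; beyond the scatter) shows that a 3-nitrophenyl in place of a 4-chlorophenyl went with a lower number, but that step exchanges the group as well as its position, so it does not isolate the move of the chloro alone. Nothing here tests chloro at the new position directly. Compound 4 is therefore expected to show a step of about a 1.2-fold lower number from compound 3 to compound 4 (0.08 log units; within the scatter) in this assay, which is within the scatter. Compound 4 is estimated at 65000 nM, with a range from 30000 nM to 140000 nM.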

Compound 4, half-maximal cytotoxic concentration: 68600 nM
For compound 4 the middle estimate is 1.1-fold (0.02 log units) below the measured one; measured number inside the range.
By their numbers in this assay, from the lowest: compound 2; then compounds 1, 4 and 3 (each within the scatter of the next).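

In this assay, among these compounds, the move from 4-chlorophenyl to 3-chlorophenyl on the saturated chain carbon (a 1.1-fold lower number from compound 3 to compound 4 (0.06 log units; within the scatter)) tests the place of the chloro alone for the first time, and that place makes no difference beyond the scatter. Chloro at the new position also stays level with the unsubstituted phenyl (a 1.1-fold higher number from compound 1 to compound 4 (0.03 log units; within the scatter)), so neither chloro compound separates from compound 1. The exchange of nitro for chloro at one and the same position (a 2.4-fold higher number from compound 2 to compound 4 (0.38 log units; beyond the scatter)) now shows that compound 2 stands apart through the group itself, which the earlier step from compound 2 to compound 3 could not isolate.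

No measurement at hand accounts for that gap. Whether the lower number is peculiar to nitro stays open, since no other group on this phenyl, such as an amine, a methoxy or a carboxylic acid, appears among the compounds shown.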